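Swapping the sulfonyl group: what solubility might follow

The compounds below may be only part of what the source reports. "The series", "measured", "known", "first", "only" and "open" are said of these compounds alone.

Compound 1 `O=C(NCc1ccc(S(=O)(=O)c2cccc(C(F)(F)F)c2)cc1)N1Cc2ccncc2C1`: 10000 nM
Compound 2 `CC(C)n1cc(S(=O)(=O)c2ccc(CNC(=O)N3Cc4ccncc4C3)cc2)cn1`: 192000 nM

In a physicochemical assay for solubility, in phosphate buffer, with a stated time of 24 h, at pH 7.4, tested at 100 uM (a lower number here means a less soluble compound, a higher number a more soluble compound), compound 2 stands highest of the two measured compounds, at 192000 nM. Its nearest and only comparison is compound 1, at 10000 nM. Going by the values given here, the one measured step places 1-isopropyl-1H-pyrazol-4-yl in place of 3-(trifluoromethyl)phenyl on a sulfonyl sulfur, and it is large: a 19-fold higher number from compound 1 to compound 2 (1.28 log units; beyond the scatter).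

Compound 3 `O=C(NCc1ccc(S(=O)(=O)C2CCC(F)(F)CC2)cc1)N1Cc2ccncc2C1` changes that same place again, with 4,4-difluorocyclohexyl in place of 1-isopropyl-1H-pyrazol-4-yl on a sulfonyl sulfur. No measurement covers this exact swap, so the guide is indirect. The entering group has fluorine and no nitrogen, as does the 3-(trifluoromethyl)phenyl of compound 1, which gives 10000 nM. Unlike that group, it is non-aromatic. Among the compounds with values here, a fall in this assay beyond the scatter is therefore expected, probably smaller than the one measured step, and a single step leaves the range wide.

The expected change is a 4.8-fold lower number from compound 2 to compound 3 (0.68 log units; beyond the scatter). For compound 3 the estimated value is 40000 nM, with an expected range of 12000 nM to 130000 nM.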

Compound 3, solubility: 35000 nM
For compound 3 the middle estimate is 1.1-fold (0.06 log units) above the measured one, and the stated range covers the measured number.
By their numbers in this assay, from the lowest: compound 1; then compound 3; then compound 2.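

In this assay the place on the sulfonyl sulfur now holds three different groups, and 4,4-difluorocyclohexyl falls at neither extreme: it gives a 5.5-fold lower number from compound 2 to compound 3 (0.74 log units; beyond the scatter) when it replaces 1-isopropyl-1H-pyrazol-4-yl, yet a 3.5-fold higher number from compound 1 to compound 3 (0.54 log units; beyond the scatter) when it replaces 3-(trifluoromethyl)phenyl. Fluorine without nitrogen therefore does not fix the number, since compound 1 and compound 3 both fit that description and their step is beyond the scatter. Nor does an aromatic ring at this place set the number by itself, since the two aromatic groups give the lowest result, in compound 1, and the highest, in compound 2, while the non-aromatic ring of compound 3 ranks above the first and under the second.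

Nothing shown here offers a measured explanation for this order. As far as these compounds go, it also remains open how a plain cyclohexyl ring without fluorine, or a ring carrying an amine, would rank at this place, and so whether the fluorines or the ring itself account for the standing of compound 3.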